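This account rests on a few compounds, and the source may have more. Where it says the series, first, only, none or still open, it means among the compounds named here.

In a functional assay on A549 cells (Homo sapiens) for inhibition, read by colorimetric assay and MTT assay, with a stated time of 72 h (on this read-out higher numbers stand for weaker inhibition and lower numbers for stronger inhibition), compound 1 (`C=CCCCCOc1ccccc1-c1cnc(OCCCCC=C)n1C`) gives 7000 nM, compound 2 (`C=CCCCCOc1ncc(-c2ccccc2OC)n1C`) gives 5000 nM and compound 3 (`COc1ccccc1-c1cnc(OCCCc2ccccc2)n1C`) gives 3000 nM. Compound 1 thus stands at the upper end of a narrow set of numbers. Compound 2 cannot be told apart from it, and only compound 3 lies beyond the scatter from it.

Compound 4 (`C=CCCCCOc1ccccc1-c1cnc(S(=O)(=O)c2ccccc2)n1C`) differs from compound 1 in one place: phenylsulfonyl in place of (hex-5-en-1-yl)oxy on an aromatic carbon. Phenylsulfonyl takes the place of (hex-5-en-1-yl)oxy on an aromatic carbon, between two ring nitrogen atoms.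

Among the measured compounds shown here, two measured steps bear on this, both only loosely. Shortening the chain on the other oxygen gave a 1.4-fold lower number from compound 1 to compound 2 (0.15 log units; within the scatter). Placing phenyl in the chain at the carbon now in question gave a 1.7-fold lower number from compound 2 to compound 3 (0.22 log units; within the scatter). For the measured compounds named here, both stayed within the scatter, and neither removes the oxygen link, so the data hold no direct precedent for a sulfonyl group. No step beyond the scatter is therefore expected, though a small move towards lower numbers seems likelier than one towards higher numbers. The expected step is a 1.8-fold lower number from compound 1 to compound 4 (0.24 log units; within the scatter). For compound 4 the estimated value is 4000 nM, with an expected range from 1200 nM to 12000 nM.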

Compound 4, half-maximal inhibitory concentration: 38000 nM
The estimate for compound 4 lay 9.5-fold (0.98 log units) below the measured number; measured number above the stated range.
By their numbers in this assay, from the lowest: compounds 3, 2 and 1 (each within the scatter of the next, the first and the last beyond it); then compound 4.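

In this assay, replacing (hex-5-en-1-yl)oxy with phenylsulfonyl on the aromatic carbon between two ring nitrogen atoms gave a 5.4-fold higher number from compound 1 to compound 4 (0.73 log units; beyond the scatter), so inhibition became weaker. Among the compounds shown here, this is the first single change to move the number beyond the scatter: the earlier changes, which kept an oxygen on the aromatic ring, gave a 1.4-fold lower number from compound 1 to compound 2 (0.15 log units; within the scatter) and a 1.7-fold lower number from compound 2 to compound 3 (0.22 log units; within the scatter), both within it, so this carbon tolerates some variation in the chain on its oxygen but not this replacement of the whole oxygen-linked group. No measurement offered here explains the loss of inhibition.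

The change swaps the link and the group it carries in one step, so the compounds shown cannot separate the contribution of the sulfonyl link from that of the phenyl ring or from the loss of the hex-5-en-1-yl chain. A phenoxy group or a hex-5-en-1-ylsulfonyl group on this carbon would pull these apart, while an amine there would show whether another link can stand in for the oxygen.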